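Swapping the sulfonyl substituent on a thiophene-bearing enone

The source may report more compounds than this note shows. Statements on the series, on what has been measured and on what is new or still open speak of the compounds shown alone.

Measured compounds:
- compound 1, `CSc1ccc(/C=C(\C(=O)c2ccc(Cl)cc2)S(=O)(=O)Cc2ccc(Cl)cc2)cc1`: 10000 nM
- compound 2, `Cc1cc(C)cc(/C=C(\C(=O)c2ccc(Cl)cc2)S(=O)(=O)Cc2ccc(Cl)cc2)c1`: 1000 nM
- compound 3, `Cc1ccc(S(=O)(=O)/C(=C/c2sccc2C)C(=O)c2ccc(Cl)cc2)cc1`: 10000 nM

All three were tested in a functional assay on DU-145 cells (Homo sapiens) for inhibition, read by trypan blue exclusion, with a stated time of 96 h; a higher number here means a weaker inhibitor of growth, a lower number a stronger inhibitor of growth. Compound 3 stands level with compound 1 at the digits given, and together they hold the highest of the three numbers, so they are the weaker growth inhibitors here. Going by the values given here, compound 2 sits apart: the one measured step, a 10-fold lower number from compound 1 to compound 2 (1.00 log units; beyond the scatter), shows that replacing the aryl group on the double-bonded chain carbon can move the number well beyond the scatter.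

Compound 4, `Cc1ccsc1/C=C(\C(=O)c1ccc(Cl)cc1)S(=O)(=O)Cc1ccc(Cl)cc1`, keeps the core of compound 3 but changes the group on the sulfonyl sulfur: 4-chlorobenzyl in place of 4-methylphenyl on a sulfonyl sulfur. Among the compounds with values here, no measured step touches this position; compounds 1 and 2 both already carry the 4-chlorobenzyl group on the sulfonyl sulfur, and the only measured step concerns a different part of the molecule. The data therefore give no reason to expect a move beyond the scatter in this assay for this change.

Compound 4 is accordingly estimated at 10000 nM, within 3000 nM to 30000 nM. The step this implies, no change at the digits printed from compound 3 to compound 4 (within the scatter), is expected to stay within the scatter.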

Compound 4, concentration for 50% growth inhibition: 25000 nM
For compound 4 the middle estimate is 2.5-fold (0.40 log units) below the measured one, within the range that was stated.
By their numbers in this assay, from the lowest: compound 2; then compounds 1 and 3 (each within the scatter of the next); then compound 4.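

In this assay, the group on the sulfonyl sulfur turns out to matter: 4-chlorobenzyl in place of 4-methylphenyl moves the number beyond the scatter, towards weaker growth inhibition (a 2.5-fold higher number from compound 3 to compound 4 (0.40 log units; beyond the scatter)). Compound 4 also widens the picture of the group on the double-bonded chain carbon. Going by these compounds alone, with 4-chlorobenzyl held fixed, 3-methylthiophen-2-yl compares poorly with 3,5-dimethylphenyl (a 25-fold higher number from compound 2 to compound 4 (1.40 log units; beyond the scatter)) and more narrowly with 4-(methylsulfanyl)phenyl (a 2.5-fold higher number from compound 1 to compound 4 (0.40 log units; beyond the scatter)), so that position spans a larger range than the single earlier step could show. Nothing measured here bears on why these numbers move.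

Going by these compounds, the sulfonyl step rests on one pair of compounds, both carrying the 3-methylthiophen-2-yl group, so it remains open whether the same swap would shift the number similarly alongside 3,5-dimethylphenyl, the group found in the lowest-numbered compound. On these data alone, it is also open how a plain methyl, a longer chain, or a group carrying an amine or a carboxylic acid on the sulfonyl sulfur would behave in this growth assay.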